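The compounds below may be only part of what the source reports. "The series", "measured", "known", "first", "only" and "open" are said of these compounds alone.

Measured so far:
compound 1, `CN1CCN(c2ccc(Nc3nc(-c4cccc(NC(=O)c5ccccc5F)c4)sc3C(=O)O)cc2)CC1`, 6300 nM
compound 2, `CN1CCN(c2ccc(Nc3nc(-c4cccc(NC(=O)c5ccc(C(F)(F)F)cc5)c4)sc3C(N)=O)cc2)CC1`, 1580 nM

In a functional assay on Ramos cells (Homo sapiens) for antiproliferative activity, read by CCK-8 assay, with a stated time of 72 h (a higher number here means a weaker inhibitor, a lower number a stronger inhibitor), compound 2 gives 1580 nM, the lower of the two numbers; its gap to compound 1 lies beyond the usual scatter of this assay. Compound 3, `CN1CCN(c2ccc(Nc3nc(-c4cccc(NC(=O)c5ccc(Cl)cc5)c4)sc3C(N)=O)cc2)CC1`, differs from compound 2 in one place, chloro in place of trifluoromethyl on an aromatic carbon, para to a large group. Among the compounds with values here, no measured pair shows this same change, so the expected step is small, a 1.1-fold higher number from compound 2 to compound 3 (0.06 log units; within the scatter), in no direction beyond the scatter. Compound 3 is therefore estimated at 1800 nM, with a range from 700 nM to 4500 nM.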

Compound 3, half-maximal inhibitory concentration: 1360 nM
For compound 3 the middle estimate is 1.3-fold (0.12 log units) above the measured one; low and high end bracket the measured number.
By their numbers in this assay, from the lowest: compounds 3 and 2 (each within the scatter of the next); then compound 1.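

In this assay, replacing trifluoromethyl with chloro on the aromatic carbon para to a large group gives a 1.2-fold lower number from compound 2 to compound 3 (0.07 log units; within the scatter), a step within the scatter. At this position, the 4 heavy atoms of trifluoromethyl can therefore give way to a single chlorine with no measurable change in this read-out. Nothing measured here bears on why the two groups read alike. Still open, on these data alone, is how an amine, a methoxy group or a nitrile on this same carbon would read, since trifluoromethyl and chloro both count 0 hydrogen-bond donors and 0 acceptors.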